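This account rests on a few compounds, and the source may have more. Where it says the series, first, only, none or still open, it means among the compounds named here.

Measured compounds:
Compound 1 `Cn1ccc2cc(-c3ccc4oc(NC5CCCCC5)nc4c3)ccc21` gives 911 nM in an assay on HEK293 cells for inhibition of Fatty-acid amide hydrolase 1 (Homo sapiens), read by fluorescence; a higher number here means a weaker inhibitor, a lower number a stronger inhibitor.
Compound 2 `CCn1ccc2cc(-c3ccc4oc(NC5CCCCC5)nc4c3)ccc21` gives 207 nM in this assay.
Compound 3 `c1cc2c(ccn2C2COC2)cc1-c1ccc2oc(NC3CCCCC3)nc2c1` gives 579 nM in this assay.

Compound 1 stands with the highest number of the three. Its nearest neighbour is compound 3, reached by a 1.6-fold lower number from compound 1 to compound 3 (0.20 log units; within the scatter), a gap that stays within the scatter; the furthest is compound 2, reached by a 4.4-fold lower number from compound 1 to compound 2 (0.64 log units; beyond the scatter). Between compound 2 and compound 3 the step is a 2.8-fold higher number from compound 2 to compound 3 (0.45 log units; beyond the scatter). All three measured steps concern the group on the aromatic nitrogen of the shared core and leave the cyclohexylamino group untouched.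

Compound 4 `Cn1ccc2cc(-c3ccc4oc(Nc5ccccc5)nc4c3)ccc21` differs from compound 1 in a different place: phenyl in place of cyclohexyl on a nitrogen on an aromatic ring. Going by the values given here, no measured step touches this nitrogen, so nothing in the set sizes this change, and the expectation rests on the absence of any comparable step rather than on one. On that basis the expected change for compound 4 in this assay is written as a 2.0-fold higher number from compound 1 to compound 4 (0.30 log units; within the scatter), with the direction uncertain. Compound 4 is therefore estimated at 1800 nM, with a range from 400 nM to 8000 nM.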

Compound 4, half-maximal inhibitory concentration: 48 nM
Compound 4: middle estimate off by 38-fold (1.57 log units), on the high side; the whole stated range lies above it.
By their numbers in this assay, from the lowest: compound 4; then compound 2; then compounds 3 and 1 (each within the scatter of the next).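

In this assay, the change from cyclohexylamino to anilino gives a 19-fold lower number from compound 1 to compound 4 (1.28 log units; beyond the scatter), larger than the biggest step on the aromatic nitrogen of the shared core, a 4.4-fold lower number from compound 1 to compound 2 (0.64 log units; beyond the scatter). The only counted difference between the two groups is that the six-membered ring is aromatic in phenyl and non-aromatic in cyclohexyl; both hold 6 heavy atoms, with no hydrogen-bond donors or acceptors. Nothing at hand explains the size of this step.

Going by these compounds, the change is read only with the methyl group on the aromatic nitrogen, so it remains open whether it carries over to the ethyl group of compound 2 or the oxetan-3-yl group of compound 3. Also open, on these data alone, is how a benzyl group on this nitrogen, or a fluorine or methoxy group on the phenyl ring, would read.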